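The compounds below may be only part of what the source reports. "The series", "measured", "known", "first", "only" and "open" are said of these compounds alone.

In an assay on isolated protein for inhibition of DNA topoisomerase 1 (Homo sapiens), with a stated time of 30 min, tested at 100 uM (on this read-out lower numbers stand for less inhibition and higher numbers for more inhibition at the one concentration tested (going by the name of the read-out)), compound 2 `Clc1ccc(-c2cc(-c3ccco3)nc(-c3ccc(Cl)s3)c2)o1` gives 23.1%, the higher of the two numbers recorded, while compound 1 `Clc1cccc(-c2cc(-c3ccoc3)cc(-c3ccc(Cl)s3)n2)c1` gives 2.1%, a gap that lies beyond the usual scatter. Compound 3 `Clc1cccc(-c2cc(-c3ccc(Cl)o3)cc(-c3ccc(Cl)s3)n2)c1` has not yet been measured in this assay. It differs from compound 2 in a single place: 3-chlorophenyl in place of furan-2-yl on an aromatic carbon. Compound 1 also carries a 3-chlorophenyl group and gives only 2.1%, so a clear drop is anticipated rather than no change. Compound 3 is therefore expected to give about 8%, within a range from 0% to 22%. The expected step is a number 15.1 percentage points lower from compound 2 to compound 3 (beyond the scatter).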

Compound 3, a percentage reported as inhibition, at one concentration (the size of the read-out at that concentration, not a potency): 13.3%
Estimate against measurement, compound 3: 5.3 percentage points below; the measured number falls inside the stated range.
By their numbers in this assay, from the lowest: compound 1; then compounds 3 and 2 (each within the scatter of the next).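

In this assay, the step of a number 9.8 percentage points lower from compound 2 to compound 3 (within the scatter) shows that 3-chlorophenyl can stand in for furan-2-yl next to the ring nitrogen with no change beyond the scatter. At the other changed carbon, with 3-chlorophenyl held fixed, 5-chlorofuran-2-yl in place of furan-3-yl gives a number 11.2 percentage points higher from compound 1 to compound 3 (beyond the scatter) and so moves the number modestly. Nothing at hand accounts for either step. From the compounds shown here alone, whether the chlorine or the furan attachment point carries that second step stays open. So does how an amine or a carboxylic acid would read next to the ring nitrogen.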